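Compound 3: pyridin-2-yl in place of the pyrazolyl group

A few compounds are considered here, and "the series" means these few. Any claim that something is new, unique, unknown or untested is made for them only; others in the source may bear on it.

Measured so far:
compound 1 `NS(=O)(=O)c1ccc(Nc2nc(N/N=C/c3ccc(C(F)(F)F)cc3)nc(Nc3ccccc3)n2)cc1` — 2610 nM
compound 2 `Cc1nn(-c2ccccc2)cc1/C=N/Nc1nc(Nc2ccccc2)nc(Nc2ccc(S(N)(=O)=O)cc2)n1` — 1710 nM

In a functional assay on A498 cells (Homo sapiens) for inhibition, read by sulforhodamine B assay, with a stated time of 48 h (on this read-out higher numbers stand for weaker inhibition of growth and lower numbers for stronger inhibition of growth), compound 2 gives 1710 nM, the lower of the two numbers shown. Its nearest neighbour is compound 1, which gives 2610 nM; the step of a 1.5-fold lower number from compound 1 to compound 2 (0.18 log units; within the scatter) lies within the scatter, so the two compounds are not separated by this assay.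

Compound 3 `NS(=O)(=O)c1ccc(Nc2nc(N/N=C/c3ccccn3)nc(Nc3ccccc3)n2)cc1` differs from compound 2 by pyridin-2-yl in place of 3-methyl-1-phenyl-1H-pyrazol-4-yl on a carbon with a double bond to nitrogen. Among the compounds with values here, no measured step covers this exact exchange. Within the data shown here, the only step available, from compound 1 to compound 2, also swapped one aryl group on the carbon with a double bond to nitrogen for another and stayed within the scatter. On that basis the step from compound 2 to compound 3 is expected to be small, a 1.3-fold higher number from compound 2 to compound 3 (0.11 log units; within the scatter), with no direction beyond the scatter. Compound 3 is therefore estimated at 2200 nM in this assay, with a range from 800 nM to 6500 nM.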

Compound 3, concentration for 50% growth inhibition: 1610 nM
For compound 3 the middle estimate is 1.4-fold (0.14 log units) above the measured one; measured number inside the range.
By their numbers in this assay, from the lowest: compounds 3, 2 and 1 (each within the scatter of the next).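

In this assay, the group on the carbon with a double bond to nitrogen drops from 12 heavy atoms and two rings to 6 heavy atoms and one ring, and the exchange gives a 1.1-fold lower number from compound 2 to compound 3 (0.03 log units; within the scatter) with no separation of the two compounds. Set against 4-(trifluoromethyl)phenyl, pyridin-2-yl gives a 1.6-fold lower number from compound 1 to compound 3 (0.21 log units; within the scatter) and so three differently built aromatic groups at this place now remain unresolved from one another. Nothing measured here accounts for this flat response.

As far as these compounds go, whether a group without an aromatic ring, such as cyclohexyl, or one carrying an amine or a carboxylic acid would move the number beyond the scatter remains open. The compounds shown also leave open how changes elsewhere on the shared core would read.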